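Acetyl removal on the shared core: working notes

The compounds below may be only part of what the source reports. "The series", "measured", "known", "first", "only" and "open" are said of these compounds alone.

- compound 1 `C=C1CC[C@@H]2[C@](C)(COC(C)=O)[C@H](OC(C)=O)CC[C@@]2(C)[C@@H]1C/C=C1/C(=O)OC[C@H]1OC(C)=O` gives 10.8 uM
- compound 2 `C=C1CC[C@@H]2[C@](C)(CO[Si](C(C)C)(C(C)C)C(C)C)[C@H](OC(C)=O)CC[C@@]2(C)[C@@H]1C/C=C1/C(=O)OC[C@H]1OC(C)=O` gives 13.6 uM
- compound 3 `C=C1CC[C@@H]2[C@](C)(CO)[C@H](OC(C)=O)CC[C@@]2(C)[C@@H]1C/C=C1/C(=O)OC[C@H]1OC(C)=O` gives 10.2 uM

The read-out throughout is a functional assay on Col2 cells (Homo sapiens) for cytotoxicity, read by sulforhodamine B assay; a higher number here means that more compound is needed for the effect, a lower number that less compound is needed. On it, compound 1 gives 10.8 uM and stands within the scatter of both other measured compounds, so no order can be read among the three.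

Compound 4 `C=C1CC[C@@H]2[C@](C)(COC(C)=O)[C@H](O)CC[C@@]2(C)[C@@H]1C/C=C1/C(=O)OC[C@H]1OC(C)=O` has not been measured. Its difference from compound 1 is hydrogen in place of acetyl on an oxygen on a saturated carbon. This is acetoxy to hydroxy, on an oxygen on a saturated carbon whose other neighbours are: saturated ring carbon.

Among the measured compounds shown here, three measured steps bear on this change. The closest is a 1.1-fold lower number from compound 1 to compound 3 (0.02 log units; within the scatter), which is also hydrogen in place of acetyl on an oxygen on a saturated carbon, though at a different oxygen of the core. The larger exchanges on that same oxygen are a 1.3-fold higher number from compound 1 to compound 2 (0.10 log units; within the scatter) and a 1.3-fold lower number from compound 2 to compound 3 (0.12 log units; within the scatter), and neither leaves the scatter. For the measured compounds named here, no measured compound carries hydroxy at the place that changes in compound 4, so the transfer from those steps remains untested.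

No step beyond the scatter is therefore expected in this assay. The expected size is a 1.1-fold lower number from compound 1 to compound 4 (0.03 log units; within the scatter), which is an estimate. Compound 4 is expected at 10 uM, with an estimated range of 6 uM to 17 uM.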

Compound 4, concentration for half-maximal effect: 15.2 uM
Beside the measured number, compound 4's estimate is 1.5-fold (0.18 log units) below it; low and high end bracket the measured number.
By their numbers in this assay, from the lowest: compounds 3, 1, 2 and 4 (each within the scatter of the next).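

In this assay, the change from acetoxy to hydroxy on an oxygen on a saturated carbon whose other neighbours are: saturated ring carbon now has a direct reading at this place: a 1.4-fold higher number from compound 1 to compound 4 (0.15 log units; within the scatter) and the free hydroxy therefore leaves the number within the scatter of the acetylated parent. Set alongside a 1.1-fold lower number from compound 1 to compound 3 (0.02 log units; within the scatter) at the other oxygen, hydrogen in place of acetyl has now been read at two oxygens of the shared core, with neither step leaving the scatter and no compound shown going against this within the series. Nothing available explains this outcome or links it to any property of the acetyl or hydroxy groups.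

Still open, going by these compounds, is whether a different group on this oxygen, such as a benzoyl ester, a methyl ether or a longer acyl chain, or an amine in place of the oxygen, would give a step beyond the scatter. Among the compounds shown here, also open is whether hydroxy at both of these oxygens together, or loss of the remaining acetoxy on the core, would stay within the scatter as the single exchanges do.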